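Sulfur substituents: from compound 2 to compound 4

The source may report more compounds than this note shows. Statements on the series, on what has been measured and on what is new or still open speak of the compounds shown alone.

Measured in a functional assay on HT-29 cells (Homo sapiens) for inhibition, read by MTT assay, with a stated time of 48 h; a higher number here means a weaker inhibitor, a lower number a stronger inhibitor (each entry is a limit):
compound 1 `COc1ccc(-n2c(S)nnc2-c2cc(OC)c(OC)c(OC)c2)cc1`: > 60000 nM
compound 2 `CCSc1nnc(-c2cc(OC)c(OC)c(OC)c2)n1-c1ccc(OC)cc1`: > 60000 nM
compound 3 `COc1ccc(-n2c(SCc3ccc(C)cc3)nnc2-c2cc(OC)c(OC)c(OC)c2)cc1`: > 60000 nM

Compound 2 gives > 60000 nM as a limit and not as a number. Among the measured compounds shown here, the series so far shows only the limit of > 60000 nM in this assay, at which 3 of the 3 values shown sit, and therefore no order among its members.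

Next in line is compound 4 `COc1ccc(CSc2nnc(-c3cc(OC)c(OC)c(OC)c3)n2-c2ccc(OC)cc2)cc1` with the change from compound 2 counted as 4-methoxyphenyl in place of methyl on a saturated chain carbon bound to a sulfur in the sulfur substituent. In words, this is 4-methoxyphenyl in place of methyl on a saturated chain carbon bound to a sulfur, or ethyl to 4-methoxybenzyl.

The closest measured change is a step that the two limits leave unreadable from compound 2 to compound 3 where 4-methylphenyl takes the same place. Also relevant are a step that the two limits leave unreadable from compound 1 to compound 2 and a step that the two limits leave unreadable from compound 1 to compound 3 on the same sulfur. None of these gives a size or a direction to carry over. Compound 3 holds the nearest group and gives > 60000 nM as a limit, so the same limit is the likeliest expected outcome for the next compound, though a readable number cannot be excluded.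

The estimate amounts to a step that the limit leaves unreadable from compound 2 to compound 4 as expected here. Compound 4 is expected at 70000 nM with an estimated range from 25000 nM to 150000 nM in this assay and a report as a limit is the likeliest form.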

Compound 4, half-maximal inhibitory concentration: > 60000 nM
Compound 4 ended at the assay's limit; the forecaster's own chance of this, stated with the estimate: 75%; the middle value is on the limit's open side.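

In this assay, among the compounds shown here, compound 4 gives > 60000 nM, a limit and not a number, so no step from compound 1, compound 2 or compound 3 to compound 4 can be read. The compounds shown leave open whether any sulfur substituent gives a readable value in this assay, and with it any order among them.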